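Methyl Substitution and Solubility Across Two Aromatic Rings

The source may hold more compounds than are shown below. What is called first, only, known or untested is meant among the compounds shown, and "the series" means these compounds.

Compound 1 `Cn1cc(-c2cnc3[nH]cc(-c4ccccc4)c3c2)cn1` is the most soluble of the three measured compounds: in a physicochemical assay for solubility, read by LC-MS, in phosphate buffer, measured as thermodynamic solubility, with a stated time of 24 h, at pH 7.4 (on this read-out lower numbers stand for lower solubility and higher numbers for higher solubility), compound 1 gives 20000 nM. Compound 2 `Cc1ccc(-c2c[nH]c3ncc(-c4cnn(C)c4)cc23)cc1` shares its core and differs from it only by methyl in place of hydrogen on an aromatic carbon; in this assay compound 2 gives 7000 nM, so that this change produced a 2.9-fold lower number from compound 1 to compound 2 (0.46 log units; beyond the scatter). Compound 3 `Cc1nn(C)cc1-c1cnc2[nH]cc(-c3cccc(C#N)c3)c2c1` differs from compound 1 in more than one place, and the difference between the two cores is not broken down here. In this assay compound 3 gives 2000 nM, the lowest number of the three and beyond the scatter from both of the others.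

Compound 4 `Cc1nn(C)c(C)c1-c1cnc2[nH]cc(-c3cccc(C#N)c3)c2c1` has not yet been measured. Relative to compound 3 it carries methyl in place of hydrogen on an aromatic carbon. Within the data shown here, this is the same kind of change as the one from compound 1 to compound 2, but not the same change: there the methyl entered on a six-membered aromatic ring of carbon only, para to a large group; here it enters on a five-membered aromatic ring with 2 nitrogen, next to the ring nitrogen and next to the ring atom that bears a methyl group. Among the measured compounds shown here, the step from compound 1 to compound 2, a 2.9-fold lower number from compound 1 to compound 2 (0.46 log units; beyond the scatter), is the only precedent available. On that basis a step of similar direction and size is expected for compound 4, a 2.5-fold lower number from compound 3 to compound 4 (0.40 log units; beyond the scatter). Compound 4 is accordingly estimated to reach 800 nM in this assay, with a range from 300 nM to 2000 nM.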

Compound 4, solubility: 5700 nM
The estimate for compound 4 lay 7.1-fold (0.85 log units) below the measured number; measured number outside the range, above it.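

Going from 1,3-dimethyl-1H-pyrazol-4-yl to 1,3,5-trimethyl-1H-pyrazol-4-yl gave a 2.9-fold higher number from compound 3 to compound 4 (0.45 log units; beyond the scatter) in this assay, whereas methyl in place of hydrogen on the six-membered aromatic ring of carbon only had given a 2.9-fold lower number from compound 1 to compound 2 (0.46 log units; beyond the scatter), so the two steps of the same kind run in opposite directions. Among these compounds, this shows that, in this series, the direction of a methyl-for-hydrogen step did not carry over from one place to another, but with only two such steps it does not show whether the ring that takes the methyl, the surrounding structure or both set the direction. Nothing measured here accounts for the rise in the number from the added methyl on the five-membered ring, and the reason for the reversal remains unexplained.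

The compounds shown leave open whether an ethyl group, a methoxy group or an amine on that same aromatic carbon of the five-membered ring would move the number in the same direction as the methyl. They also leave open how the same methyl step would read on the five-membered ring of compound 1, where the nitrile is absent.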